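Swapping a methoxy for a nitro on the aryl ring

The compounds below may be only part of what the source reports. "The series", "measured", "known", "first", "only" and "open" are said of these compounds alone.

Measured compounds:
- compound 1, `Cc1ccccc1-c1nnc(CSc2nnc(/N=C/c3ccccc3O)s2)o1`: 7850 nM
- compound 2, `COc1ccc(-c2nnc(CSc3nnc(/N=C/c4ccccc4O)s3)o2)cc1`: 20300 nM

Among the compounds with values here, in a functional assay on A549 cells (Homo sapiens) for inhibition, read by CCK-8 assay (a lower number here means a stronger inhibitor, a higher number a weaker inhibitor), compound 2 gives the highest of the two numbers known here; its nearest neighbour is compound 1, and the step of a 2.6-fold higher number from compound 1 to compound 2 (0.41 log units; beyond the scatter) lies beyond the scatter. Compound 3, `O=[N+]([O-])c1ccc(-c2nnc(CSc3nnc(/N=C/c4ccccc4O)s3)o2)cc1`, has not been measured. It differs from compound 2 by nitro in place of methoxy on an aromatic carbon. Within the data shown here, no measured step bears on this change: the single known step concerns a 4-methoxyphenyl in place of a 2-methylphenyl and says nothing about a nitro in place of a methoxy. With nothing to lean on, compound 3 is expected to sit near compound 2, with a step of a 1.4-fold lower number from compound 2 to compound 3 (0.13 log units; within the scatter) that may well fall within the scatter. In this assay compound 3 is therefore estimated at 15000 nM, within a broad range from 5000 nM to 45000 nM.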

Compound 3, half-maximal inhibitory concentration: 4130 nM
For compound 3 the middle estimate is 3.6-fold (0.56 log units) above the measured one; measured number outside the range, below it.
By their numbers in this assay, from the lowest: compounds 3 and 1 (each within the scatter of the next); then compound 2.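

In this assay this position proves sensitive to the group it carries: with the place on the ring held fixed, going from 4-methoxyphenyl to 4-nitrophenyl gives a 4.9-fold lower number from compound 2 to compound 3 (0.69 log units; beyond the scatter), whereas the earlier step changed the group and its place together. The 4-nitrophenyl and 2-methylphenyl compounds do not separate, since a 1.9-fold lower number from compound 1 to compound 3 (0.28 log units; within the scatter) stays within the scatter, which leaves compound 2 alone apart from the other two. Nothing at hand accounts for the size of the step between the methoxy and nitro groups.

From the compounds shown here alone, whether an amine, a nitrile or a carboxylic acid at the same place would track the nitro group or the methoxy group remains open. So does the outcome of moving the nitro group elsewhere on the ring, or of replacing the hydroxyl group on the other aryl ring of the shared core.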